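The source may hold more compounds than are shown below. What is called first, only, known or untested is meant among the compounds shown, and "the series" means these compounds.

Three compounds share one core and differ in the group on a saturated chain carbon bound to a sulfur. In a functional assay on HepG2 cells (Homo sapiens) for antiproliferative activity, read by MTT assay, with a stated time of 24 h (a lower number here means a stronger inhibitor, a higher number a weaker inhibitor), compound 1 `O=[N+]([O-])c1cccc(CSc2nnc(-c3ccc4c(c3)OCCO4)n2-c2ccccc2)c1` gives 49300 nM while compound 2 `O=[N+]([O-])c1ccc(CSc2nnc(-c3ccc4c(c3)OCCO4)n2-c2ccccc2)cc1` gives 13800 nM and compound 3 `Cc1ccccc1CSc1nnc(-c2ccc3c(c2)OCCO3)n1-c1ccccc1` gives 20500 nM as its reading. Compound 3 cannot be told apart from compound 2, and both lie clearly under compound 1. Compound 4 `Fc1cccc(F)c1CSc1nnc(-c2ccc3c(c2)OCCO3)n1-c1ccccc1` differs from compound 3 by 2,6-difluorophenyl in place of 2-methylphenyl on a saturated chain carbon bound to a sulfur at that same place. The measured swaps give a 3.6-fold lower number from compound 1 to compound 2 (0.55 log units; beyond the scatter) and a 2.4-fold lower number from compound 1 to compound 3 (0.38 log units; beyond the scatter) as modest changes, with a 1.5-fold higher number from compound 2 to compound 3 (0.17 log units; within the scatter) inside the scatter. None of these compounds carries fluorine, so no direction follows, and no change beyond the scatter is expected in this assay here. The expected step is a 1.0-fold lower number from compound 3 to compound 4 (0.01 log units; within the scatter) by this estimate. The estimated value for compound 4 is 20000 nM with 9000 nM to 45000 nM as its range.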

Compound 4, half-maximal inhibitory concentration: 2070 nM
Estimate against measurement, compound 4: 9.7-fold (0.99 log units) above, outside the stated range (below it).
By their numbers in this assay, from the lowest: compound 4; then compounds 2 and 3 (each within the scatter of the next); then compound 1.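

In this assay, the group on a saturated chain carbon bound to a sulfur can shift the number further than the earlier swaps showed: 2,6-difluorophenyl gives a 9.9-fold lower number from compound 3 to compound 4 (1.00 log units; beyond the scatter), a 6.7-fold lower number from compound 2 to compound 4 (0.82 log units; beyond the scatter) and a 24-fold lower number from compound 1 to compound 4 (1.38 log units; beyond the scatter). For the compounds shown here, compound 4 is the only fluorine-bearing compound here, and it has the lowest number, with each step to it beyond the scatter. Nothing available explains this gain. Going by these compounds, it remains open whether 2-fluorophenyl, with a single fluorine, or 2,6-dichlorophenyl would match compound 4.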